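From compound 3 to compound 4: one aryl group changes

The source may report more compounds than this note shows. Statements on the series, on what has been measured and on what is new or still open speak of the compounds shown alone.

Measured so far in a functional assay on MDA-MB-231 cells (Homo sapiens) for cytotoxicity, read by MTT assay, with a stated time of 48 h; a lower number here means a stronger inhibitor, a higher number a weaker inhibitor
Compound 1 `Cc1ccc(NC(=O)NCCCCC(c2ccc(F)cc2)c2ccc(F)cc2)cc1` gives > 20000 nM (a limit of the assay)
Compound 2 `O=C(NCCCCC(c1ccc(F)cc1)c1ccc(F)cc1)Nc1cccc([N+](=O)[O-])c1` gives 3790 nM
Compound 3 `Cc1cccc(NC(=O)NCCCCC(c2ccc(F)cc2)c2ccc(F)cc2)c1` gives > 20000 nM (a limit of the assay)

Compound 3 offers no number to start from, only a limit of > 20000 nM. Within the data shown here, the series so far is dominated by the limit of > 20000 nM in this assay, at which 2 of the 3 values shown sit. Only compound 2 gives a readable value, 3790 nM.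

Compound 4 `Nc1cc(NC(=O)NCCCCC(c2ccc(F)cc2)c2ccc(F)cc2)ccc1Cl` carries 3-amino-4-chlorophenyl in place of 3-methylphenyl on an amide-type nitrogen.

Two measured steps show that a change on this aryl group can move this assay beyond the scatter: an at least 5.2-fold lower number from compound 1 to compound 2 (0.72 log units; beyond the scatter) and an at least 5.2-fold higher number from compound 2 to compound 3 (0.72 log units; beyond the scatter). The third, a step that the two limits leave unreadable from compound 1 to compound 3, adds nothing on size. Among the measured compounds shown here, no measured compound carries an amino or a chloro group, so these steps are only a loose guide. For the measured compounds named here, compound 2 at 3790 nM is the sole precedent for a readable value, which leads to the expectation of a modest move toward a lower number. A further limit remains quite possible. The expected step is an at least 2.2-fold lower number from compound 3 to compound 4 (0.34 log units; beyond the scatter).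

The estimate for compound 4 is 9000 nM, with an expected range of 3000 nM to 20000 nM.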

Compound 4, half-maximal inhibitory concentration: 9240 nM
Compound 4: middle estimate off by 1.0-fold (0.01 log units), on the low side, within the range that was stated.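

In this assay, among these compounds, compound 4 shows that 3-nitrophenyl is not the only aryl group on this amide-type nitrogen to give a readable value, with an at least 2.1-fold lower number from compound 3 to compound 4 (0.33 log units; beyond the scatter) and an at least 2.1-fold lower number from compound 1 to compound 4 (0.33 log units; beyond the scatter). The new group does not match 3-nitrophenyl, however: the change shows a 2.4-fold higher number from compound 2 to compound 4 (0.39 log units; beyond the scatter), which leaves compound 2 the strongest of the four compounds. Compound 1 and compound 3 both remain at the limit of the assay, so their steps to compound 4 are bounds rather than sizes: the limit of > 20000 nM in this assay, at which 2 of the 4 values shown sit.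

The compounds shown leave open whether the amino group, the chloro group or the two together account for the readable value, as compound 4 brings both onto the ring in a single change. A 3-aminophenyl or a 4-chlorophenyl group on the same nitrogen would separate these two contributions.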